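The compounds below may be only part of what the source reports. "The series", "measured", "known", "first", "only" and "open" are said of these compounds alone.

Among the compounds with values here, in a functional assay on U-937 cells (Homo sapiens) for antiproliferative activity, read by MTT assay, with a stated time of 24 h (a lower number here means a stronger inhibitor, a higher number a weaker inhibitor), two compounds have numbers so far. Compound 1 (`CCCCNC(=O)COc1ccc(C(=O)c2c(CCCC)oc3ccccc23)cc1`) gives 22800 nM, and compound 2 (`CCCCc1oc2ccccc2c1C(=O)c1ccc(OCC(=O)N2CCN(C(=O)OC(C)(C)C)CC2)cc1`) gives 23700 nM. These two values lie within the usual scatter of each other, so compound 1 stands level with compound 2, and neither can be called the stronger inhibitor.

The next compound to be tested, compound 3 (`CCCCc1oc2ccccc2c1C(=O)c1ccc(OCC(=O)Nc2ccccc2)cc1`), keeps the core of compound 1 and differs in one place: phenyl in place of butyl on an amide-type nitrogen. Put simply, it carries phenyl in place of butyl on an amide-type nitrogen. Within the data shown here, no measured pair of compounds shows what a change of this kind does, so the data give no direct guide to its size or direction. The best starting point is the value of compound 1 at 22800 nM, and no step beyond the scatter is expected in either direction. The expected step is a 1.1-fold lower number from compound 1 to compound 3 (0.06 log units; within the scatter), although this remains uncertain. For compound 3, the estimated value is 20000 nM, with an expected range from 8000 nM to 50000 nM.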

Compound 3, half-maximal inhibitory concentration: 25900 nM
The estimate for compound 3 lay 1.3-fold (0.11 log units) below the measured number; the measured number falls inside the stated range.
By their numbers in this assay, from the lowest: compounds 1, 2 and 3 (each within the scatter of the next).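

In this assay, the change from butyl to phenyl on the amide-type nitrogen gives a 1.1-fold higher number from compound 1 to compound 3 (0.06 log units; within the scatter), so compound 1 and compound 3 stand level. Within the data shown here, this is the first measured step at this nitrogen, and it shows that replacing an open butyl chain with a six-membered aromatic ring of carbon only, which also adds to the heavy-atom count, leaves the antiproliferative read-out within the scatter; the same result can be read as butylcarbamoyl giving way to phenylcarbamoyl with no measurable consequence. Nothing measured for these compounds explains why the two numbers stay level.

A single step cannot show whether this nitrogen is insensitive to its substituent in general or whether these two groups merely happen to give similar numbers. Going by these compounds, it remains open whether a longer chain, a benzyl group, or a phenyl ring carrying an amine or a carboxylic acid at this nitrogen would give a number that differs from that of compound 1 by more than the scatter.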